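Swapping the 4-chlorophenoxy group for an imidazole

The source may hold more compounds than are shown below. What is called first, only, known or untested is meant among the compounds shown, and "the series" means these compounds.

In a functional assay for inhibition of sodium/hydrogen exchanger (Oryctolagus cuniculus) (on this read-out higher numbers stand for weaker inhibition and lower numbers for stronger inhibition), compound 1 `CCc1cc(C)c(C(=O)N=C(N)N)cc1S(C)(=O)=O` gives 4.8 nM. Compound 2 `Cc1cc(OCc2ccccc2)c(S(C)(=O)=O)cc1C(=O)N=C(N)N`, which carries benzyloxy in place of ethyl on an aromatic carbon, gives 28 nM in this assay. Compound 3 `Cc1cc(Oc2ccc(Cl)cc2)c(S(C)(=O)=O)cc1C(=O)N=C(N)N` gives 13 nM in this assay and stands second highest of the three numbers, with compound 2 as its nearest neighbour and compound 1 furthest away. The step of a 5.8-fold higher number from compound 1 to compound 2 (0.77 log units; beyond the scatter) and the step of a 2.7-fold higher number from compound 1 to compound 3 (0.43 log units; beyond the scatter) both run toward weaker inhibition, while the step of a 2.2-fold lower number from compound 2 to compound 3 (0.33 log units; beyond the scatter) runs back part of the way. Compound 4 `Cc1cc(-n2ccnc2C)c(S(C)(=O)=O)cc1C(=O)N=C(N)N` differs from compound 3 by 2-methyl-1H-imidazol-1-yl in place of 4-chlorophenoxy on an aromatic carbon. Among the compounds with values here, no measured step exchanges the 4-chlorophenoxy group for a 2-methyl-1H-imidazol-1-yl group, so the step between compound 3 and compound 4 can only be set against the modest steps among compounds 1, 2 and 3, none of which moved the number far in either direction. On that basis compound 4 is expected to stay near compound 3, with a small shift toward a higher number estimated as a 1.5-fold higher number from compound 3 to compound 4 (0.19 log units; within the scatter). The estimate for compound 4 in this assay is 20 nM, with a range from 6 nM to 70 nM.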

Compound 4, half-maximal inhibitory concentration: 29 nM
Estimate against measurement, compound 4: 1.5-fold (0.16 log units) below, and the stated range covers the measured number.
By their numbers in this assay, from the lowest: compound 1; then compound 3; then compounds 2 and 4 (each within the scatter of the next).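

In this assay, the position ortho to a methylsulfonyl group also accepts a five-membered aromatic ring with 2 hetero atoms in place of the 4-chlorophenoxy group, and this exchange gives a 2.2-fold higher number from compound 3 to compound 4 (0.35 log units; beyond the scatter), so the smaller imidazole-bearing compound stays in the same range as the earlier ones rather than departing sharply from them. Set against the other two groups, the 2-methyl-1H-imidazol-1-yl group gives a 1.0-fold higher number from compound 2 to compound 4 (0.02 log units; within the scatter), which leaves it level with benzyloxy, and a 6.0-fold higher number from compound 1 to compound 4 (0.78 log units; beyond the scatter), which means that compounds 2, 3 and 4 all stand at higher numbers than compound 1 with its ethyl group, whether the ring at this position is attached through oxygen or directly. Nothing at hand accounts for the size or direction of these steps.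

The compounds shown leave open what the plain imidazol-1-yl group, without its methyl, would give at this position, and so how much of the result belongs to that methyl. They also leave open how a saturated ring amine such as piperidin-1-yl, or a short chain ending in a carboxylic acid, would compare with the ethyl group of compound 1.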